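The source may report more compounds than this note shows. Statements on the series, on what has been measured and on what is new or still open speak of the compounds shown alone.

Three compounds built on one shared core were measured in an assay for binding affinity to dual specificity mitogen-activated protein kinase kinase 4 (Homo sapiens), read by KINOMEscan, tested at 100 nM; on this read-out lower numbers stand for a stronger effect and higher numbers for a weaker effect at the one concentration tested. Compound 1 `CCCS(=O)(=O)Nc1ccc(F)c(C(=O)c2n[nH]c3ncc(-c4cccc(Cl)c4)cc23)c1F` gives 40%, compound 2 `CCCS(=O)(=O)Nc1ccc(F)c(C(=O)c2n[nH]c3ncc(-c4cccc(C)c4)cc23)c1F` gives 15%, and compound 3 `CCCS(=O)(=O)Nc1ccc(F)c(C(=O)c2n[nH]c3ncc(-c4ccc(C)cc4)cc23)c1F` gives 5.4%. Compound 3 sits at the low end of these numbers: the step of a number 9.6 percentage points lower from compound 2 to compound 3 (within the scatter) lies within the scatter, whereas the steps of a number 34.6 percentage points lower from compound 1 to compound 3 (beyond the scatter) and a number 25 percentage points lower from compound 1 to compound 2 (beyond the scatter) lie beyond it. Compound 4 `CCCS(=O)(=O)Nc1ccc(F)c(C(=O)c2n[nH]c3ncc(-c4ccccc4N)cc23)c1F` differs from compound 3 by 2-aminophenyl in place of 4-methylphenyl on an aromatic carbon. The measured steps exchanged only chloro and methyl groups at this place and shifted the read-out by up to the largest of them; none introduced an amino group, so the direction of this step is open. Compound 4 is therefore expected to give 35%, between 8% and 75%, an expected step of a number 29.6 percentage points higher from compound 3 to compound 4 (beyond the scatter).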

Compound 4, a percentage reported as activity, at one concentration (the size of the read-out at that concentration, not a potency): 23%
Estimate against measurement, compound 4: 12 percentage points above, within the range that was stated.
By their numbers in this assay, from the lowest: compounds 3, 2 and 4 (each within the scatter of the next, the first and the last beyond it); then compound 1.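

Within the data shown here, the first group at this place to carry a hydrogen-bond donor and acceptor, 2-aminophenyl, gives a weaker read-out than 4-methylphenyl (a number 17.6 percentage points higher from compound 3 to compound 4 (beyond the scatter)) and a stronger one than 3-chlorophenyl (a number 17 percentage points lower from compound 1 to compound 4 (beyond the scatter)), with no clear difference from 3-methylphenyl (a number 8 percentage points higher from compound 2 to compound 4 (within the scatter)). This position therefore accepts an amino-bearing ring, with a read-out inside the range already spanned by the methyl and chloro compounds. Nothing available explains these shifts.

Going by these compounds, it remains open what 3-aminophenyl or 4-aminophenyl would give, which would separate the amino group's effect from that of its place on the ring. On these data alone, a hydroxyl group or a carboxylic acid on the same ring is equally open.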